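The source may report more compounds than this note shows. Statements on the series, on what has been measured and on what is new or still open speak of the compounds shown alone.

Measured compounds:
Compound 1, `N#Cc1ccc(S(=O)(=O)N2C/C(=C\c3ccccc3F)C(=O)/C(=C/c3ccccc3F)C2)cc1`: 16500 nM
Compound 2, `CC(=O)Nc1ccc(S(=O)(=O)N2C/C(=C\c3ccccc3F)C(=O)/C(=C/c3ccccc3F)C2)cc1`: 5200 nM
Compound 3, `N#Cc1ccc(S(=O)(=O)N2C/C(=C\c3ccc(F)cc3)C(=O)/C(=C/c3ccc(F)cc3)C2)cc1`: 9800 nM

The read-out throughout is a functional assay on HepG2 cells (Homo sapiens) for cytotoxicity, read by MTT assay, with a stated time of 24 h; a higher number here means a weaker inhibitor, a lower number a stronger inhibitor. Compound 1 and compound 2 share one core and differ by acetamido in place of cyano on an aromatic carbon; that change gave a 3.2-fold lower number from compound 1 to compound 2 (0.50 log units; beyond the scatter). Compound 3 carries a different core; the difference between the two cores is not broken down here. Compound 3 and compound 1 give numbers within the scatter of each other, as do compound 3 and compound 2.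

Compound 4, `CC(=O)Nc1ccc(S(=O)(=O)N2C/C(=C\c3ccc(F)cc3)C(=O)/C(=C/c3ccc(F)cc3)C2)cc1`, is not yet measured. It differs from compound 3 by acetamido in place of cyano on an aromatic carbon, the same change as that from compound 1 to compound 2. Going by the values given here, on the strength of the single earlier pair, where a 3.2-fold lower number from compound 1 to compound 2 (0.50 log units; beyond the scatter) was seen, a step of similar size is expected here, a 3.0-fold lower number from compound 3 to compound 4 (0.47 log units; beyond the scatter). For compound 4 the estimate in this assay is therefore 3300 nM, with a range from 1400 nM to 8000 nM.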

Compound 4, half-maximal inhibitory concentration: 7400 nM
Estimate against measurement, compound 4: 2.2-fold (0.35 log units) below; measured number inside the range.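

In this assay, acetamido in place of cyano on the second core gave a 1.3-fold lower number from compound 3 to compound 4 (0.12 log units; within the scatter) and so cannot be told from no change on that core alone. Set beside the earlier step, the two do not separate: the same change on two cores in this assay, a 3.2-fold lower number (0.50 log units; beyond the scatter) from compound 1 to compound 2 and a 1.3-fold lower number (0.12 log units; within the scatter) from compound 3 to compound 4, 2.4-fold (0.38 log units) apart, within the scatter of two such steps. The data therefore fit a single shared step on both cores, but two pairs do not show that the step carries over at a fixed size, nor that it depends on the core.

Still open, going by these compounds, is how an amine, a carboxylic acid or a longer acyl chain in place of the cyano would read on either core. Also open, on these data alone, is whether the two steps would agree on a core with methoxy on the outer aromatic rings instead of fluorine.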